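Adding a chloro group to compound 2

The source may report more compounds than this note shows. Statements on the series, on what has been measured and on what is new or still open speak of the compounds shown alone.

For the measured compounds named here, compound 2 (`COc1ccc(-c2nc(C)c(C(=O)CSc3nc(-c4ccccc4)c(C#N)c(=O)[nH]3)s2)cc1`) gives 57300 nM in a functional assay on U-87MG ATCC cells for antiproliferative activity against U-87 MG (Homo sapiens), read by MTT assay, with a stated time of 48 h (a lower number here means a stronger inhibitor, a higher number a weaker inhibitor), and so holds the higher of the two numbers measured so far. Going by the values given here, its only measured neighbour, compound 1 (`COc1ccc(-c2nc(C)c(C(=O)CSc3nc(-c4cccc(OC)c4)c(C#N)c(=O)[nH]3)s2)cc1`), stands lower at 15300 nM and is the stronger inhibitor of the pair.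

Compound 3 (`COc1ccc(-c2nc(C)c(C(=O)CSc3nc(-c4cccc(Cl)c4)c(C#N)c(=O)[nH]3)s2)cc1`) has not been measured yet. Its change from compound 2 is chloro in place of hydrogen on an aromatic carbon (chloro in place of hydrogen on an aromatic carbon, turning phenyl into 3-chlorophenyl).

Among the compounds with values here, one measured step bears on this: a 3.7-fold higher number from compound 1 to compound 2 (0.57 log units; beyond the scatter) when hydrogen replaces methoxy on an aromatic carbon. Read in reverse, that step links a group in place of hydrogen with a lower number. However, chloro is not methoxy, and a single step establishes no pattern, so only a modest move toward a lower number is expected. The expected size is a 2.2-fold lower number from compound 2 to compound 3 (0.34 log units; beyond the scatter) and it stays uncertain. Compound 3 is estimated at 26000 nM with an expected range from 9000 nM to 60000 nM for now.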

Compound 3, half-maximal inhibitory concentration: 78900 nM
Compound 3: the middle estimate sits 3.0-fold (0.48 log units) below what was measured; measured number above the stated range.
By their numbers in this assay, from the lowest: compound 1; then compounds 2 and 3 (each within the scatter of the next).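

In this assay, putting chloro on the phenyl ring gives a 1.4-fold higher number from compound 2 to compound 3 (0.14 log units; within the scatter), a step within the scatter, so compound 3 cannot be told apart from compound 2 and this change shows no measurable effect. The earlier step alone could have suggested that any group in place of hydrogen here lowers the number, but compound 3 goes against that reading: exchanging chloro for the methoxy of compound 1 gives a 5.2-fold higher number from compound 1 to compound 3 (0.71 log units; beyond the scatter), which lies beyond the scatter, so the identity of the group matters and, of the three compounds, only compound 1 stands apart from the other two. Nothing available explains why methoxy and chloro differ in this way.

For the compounds shown here, with only three compounds, all of them weak in this assay, methoxy remains a single example, and it is open whether a related group such as ethoxy, hydroxy or an amine would also give a lower number than hydrogen. Going by these compounds, it is also open whether methoxy or chloro would behave the same way elsewhere on this phenyl ring, since both are seen at one place only.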